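Anilinothiazole series: bromo for methyl on the aniline

The source may hold more compounds than are shown below. What is called first, only, known or untested is meant among the compounds shown, and "the series" means these compounds.

Measured compounds in a functional assay on RKO cells (Homo sapiens) for cytotoxicity, read by resazurin assay, with a stated time of 72 h; a higher number here means a weaker inhibitor, a lower number a stronger inhibitor:
compound 1 `Cc1ccc(Nc2nc(-n3ccnc3C)cs2)cc1`: 450 nM
compound 2 `COc1ccc(Nc2nc(-n3cnc4ccccc43)cs2)cc1`: > 100000 nM
compound 3 `Cc1nc2ccccc2n1-c1csc(Nc2ccc(S(N)(=O)=O)cc2)n1`: 45000 nM

Compound 1 holds the lower of the two numbers obtained in this assay. Compound 3 sits well above it, and the gap lies beyond the scatter. Compound 2 gives only a limit and no number, being reported at the limit of > 100000 nM in this assay, at which 1 of the 3 values shown sits.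

Compound 4 `Cc1nccn1-c1csc(Nc2ccc(Br)cc2)n1` is not yet measured in this assay. It differs from compound 1 in one place:

bromo in place of methyl on an aromatic carbon

Going by the values given here, no measured pair in this set differs in only one place, so the size of the step from compound 1 to compound 4 has no measured counterpart here. The exchange of one heavy atom for one heavy atom, with no change in ring count, donors, acceptors or charge, is taken to leave the value near that of compound 1, so the step is expected to fall within the scatter: a 1.1-fold lower number from compound 1 to compound 4 (0.05 log units; within the scatter). In this assay compound 4 is therefore estimated at 400 nM, with a range from 150 nM to 1200 nM.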

Compound 4, half-maximal inhibitory concentration: 30000 nM
The estimate for compound 4 lay 75-fold (1.88 log units) below the measured number; the measured number lies above the stated range.
By their numbers in this assay, from the lowest: compound 1; then compounds 4 and 3 (each within the scatter of the next). At a limit, above all of these: compound 2.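

In this assay, the step for bromo in place of methyl on an aromatic carbon, para to a large group, is a 67-fold higher number from compound 1 to compound 4 (1.82 log units; beyond the scatter) and is large. Going by these compounds alone, this is the first single-place comparison, and it shows that the number depends strongly on the group at this position. The count of heavy atoms, rings, donors, acceptors and charge stays the same across the change, so these counts do not track the value here, and nothing at hand bears on the cause of the step.

As far as these compounds go, with only methyl and bromo compared at this position, it remains open whether the methyl of compound 1 is specifically favoured or bromo is specifically disfavoured. From the compounds shown here alone, how an amine or a carboxylic acid at the same position would compare with either group also remains open.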